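From 3-nitrophenyl to naphthalen-1-yl on a shared core

The source may report more compounds than this note shows. Statements on the series, on what has been measured and on what is new or still open speak of the compounds shown alone.

Measured in a functional assay on HCT-116 cells (Homo sapiens) for inhibition, read by MTT assay, with a stated time of 48 h; on this read-out higher numbers stand for weaker inhibition and lower numbers for stronger inhibition:
Compound 1 `COc1cc(-c2cc(-c3cccc([N+](=O)[O-])c3)nc(-c3ccccc3)n2)cc(OC)c1OC`: > 25000 nM, a limit and not a number
Compound 2 `COc1cc(-c2cc(-c3cccc(O)c3)nc(-c3ccccc3)n2)cc(OC)c1OC`: 20400 nM
Compound 3 `COc1cc(-c2cc(-c3ccc(O)cc3)nc(-c3ccccc3)n2)cc(OC)c1OC`: 11900 nM

Compound 1 gives no exact value and stands at the limit of > 25000 nM in this assay, at which 1 of the 3 values shown sits. Compound 4 `COc1cc(-c2cc(-c3cccc4ccccc34)nc(-c3ccccc3)n2)cc(OC)c1OC` keeps the core of compound 1 and differs from it in one place: naphthalen-1-yl in place of 3-nitrophenyl on an aromatic carbon. Among the compounds with values here, three measured steps bear on this change, though only indirectly, since none of them brings in naphthalen-1-yl. Only one lies beyond the scatter, and it is an at least 2.1-fold lower number from compound 1 to compound 3 (0.32 log units; beyond the scatter). The other two are an at least 1.2-fold lower number from compound 1 to compound 2 (0.08 log units; that floor lies within the scatter) and a 1.7-fold lower number from compound 2 to compound 3 (0.23 log units; within the scatter). Replacing 3-nitrophenyl has so far given compound 3 a modest gain, as the value of 11900 nM for compound 3 shows, so a modest step to a lower number is expected in this assay, and it may not clear the scatter. The expected change is an at least 1.5-fold lower number from compound 1 to compound 4 (0.19 log units; that floor lies within the scatter). For compound 4 the estimated value is 16000 nM, with an expected range from 6000 nM to 30000 nM.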

Compound 4, half-maximal inhibitory concentration: 4930 nM
For compound 4 the middle estimate is 3.2-fold (0.51 log units) above the measured one; measured number below the stated range.
By their numbers in this assay, from the lowest: compound 4; then compounds 3 and 2 (each within the scatter of the next). At a limit, above all of these: compound 1.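

In this assay, within the data shown here, this position on the shared core reaches its lowest number so far with a group of two carbon-only aromatic rings and no hydrogen-bond donors or acceptors, so a hydroxy group is not needed for a gain here: the change gives a 2.4-fold lower number from compound 3 to compound 4 (0.38 log units; beyond the scatter) and a 4.1-fold lower number from compound 2 to compound 4 (0.62 log units; beyond the scatter). Against the nitro-bearing starting point, the change gives an at least 5.0-fold lower number from compound 1 to compound 4 (0.70 log units; beyond the scatter). That step is only a floor, as compound 1 stands at a limit: the limit of > 25000 nM in this assay, at which 1 of the 4 values shown sits.

From the compounds shown here alone, it remains open whether naphthalen-2-yl or an unsubstituted phenyl group would match naphthalen-1-yl at this position. The compounds shown also do not tell how an amine or a carboxylic acid would fare there, or why naphthalen-1-yl gives the lower number.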